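The compounds below may be only part of what the source reports. "The series", "measured", "known", "first", "only" and "open" are said of these compounds alone.

Series values in a functional assay on Hs 683 cells (Homo sapiens) for cytotoxicity, read by MTT assay; a higher number here means a weaker inhibitor, a lower number a stronger inhibitor:

- compound 1 `Oc1ccc(CN(Cc2ccccc2)Cc2ccc(O)c3ncccc23)c2cccnc12`: 76 nM
- compound 2 `Oc1ccc(CN(Cc2ccccc2C(F)(F)F)Cc2ccc(O)c3ncccc23)c2cccnc12`: 64 nM
- compound 3 `Oc1ccc(CN(Cc2cccc(C(F)(F)F)c2)Cc2ccc(O)c3ncccc23)c2cccnc12`: not yet measured

Compound 2, at 64 nM, stands level with compound 1 within the scatter. Compound 3 has the same atoms joined differently, with 3-(trifluoromethyl)phenyl in place of 2-(trifluoromethyl)phenyl on a saturated chain carbon bound to an amine nitrogen. Going by the values given here, only one measured step bears on this change, namely a 1.2-fold lower number from compound 1 to compound 2 (0.07 log units; within the scatter). That step introduces the trifluoromethyl in place of hydrogen on an aromatic carbon and stays within the scatter. Among the compounds with values here, no measured pair tests the 3-(trifluoromethyl)phenyl directly, so this is indirect support only. No shift beyond the scatter is expected in this assay, and no direction is favoured. The expected step is a 1.1-fold higher number from compound 2 to compound 3 (0.04 log units; within the scatter). For compound 3 the estimated value is 70 nM, with an expected range of 30 nM to 160 nM.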

Compound 3, half-maximal inhibitory concentration: 36 nM
Estimate against measurement, compound 3: 1.9-fold (0.29 log units) above, and the stated range covers the measured number.
By their numbers in this assay, from the lowest: compounds 3, 2 and 1 (each within the scatter of the next, the first and the last beyond it).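

In this assay the shift of the trifluoromethyl from 2-(trifluoromethyl)benzyl to 3-(trifluoromethyl)benzyl gives a 1.8-fold lower number from compound 2 to compound 3 (0.25 log units; within the scatter), so the compounds shown do not establish that its placement matters. Against the unsubstituted benzyl, the picture differs: a 2.1-fold lower number from compound 1 to compound 3 (0.32 log units; beyond the scatter) is modest but is the first step in the series to clear the scatter, whereas a 1.2-fold lower number from compound 1 to compound 2 (0.07 log units; within the scatter) did not. No supporting data bear on what lies behind this difference.

The compounds shown leave open whether the lower number belongs to the trifluoromethyl itself or would also appear with a chlorine, a methoxy or a nitrile at the same place. They also leave open how a carboxylic acid or an amine there would read in this assay.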